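Truncating the sulfone arm of compound 1

A few compounds are considered here, and "the series" means these few. Any claim that something is new, unique, unknown or untested is made for them only; others in the source may bear on it.

Compound 1 `CCCCc1nc(=O)c(S(=O)(=O)c2ccc(-c3ccnc(NC(=O)C4CC4)c3)cc2)c(O)n1-c1c(OC)cccc1OC` carries a butyl chain and a substituted pyridyl arm on the aryl sulfone. In an ADME assay on microsomes from liver (Homo sapiens) for metabolic stability, using NADPH, with a stated time of 10 min (a higher number here means that more of the compound is left, a lower number that less of the compound is left), compound 1 gives 84%. Compound 3 `COc1cccc(OC)c1-n1c(CCC(C)C)nc(=O)c(S(=O)(=O)c2ccc(-c3ccc(F)nc3)cc2)c1O`, with a branched chain and a fluoropyridyl arm, gives 89% in this assay; the two numbers lie within the usual scatter of each other, and compound 1 stands close to compound 3 rather than apart from it. In this assay compound 2 `CCCCc1[nH]c(=O)c(S(=O)(=O)c2ccc(-c3ccc(F)nc3)cc2)c(O)c1-c1c(OC)cccc1OC` gives "not determined" (no result reported), so no number is reported for it. Going by the values given here, no pair of measured compounds differs in a single place, and no measured step exists in this set.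

Compound 4 `CCCCc1nc(=O)c(S(=O)(=O)c2ccccc2)c(O)n1-c1c(OC)cccc1OC` removes the whole arm: hydrogen in place of 2-((cyclopropylcarbonyl)amino)pyridin-4-yl on an aromatic carbon. Both measured compounds leave most of the material intact in this assay, and the set holds nothing that points to a change in either direction. The expected step of a number 1 percentage points higher from compound 1 to compound 4 (within the scatter) is small, within the scatter. Compound 4 is estimated at 85%, with an expected range from 65% to 98%.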

Compound 4, percent of the compound remaining: 89%
The estimate for compound 4 lay 4 percentage points below the measured number; low and high end bracket the measured number.
By their numbers in this assay, from the lowest: compounds 1, 3 and 4 (each within the scatter of the next).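

Hydrogen in place of 2-((cyclopropylcarbonyl)amino)pyridin-4-yl gives the one single-place comparison in the series: in this assay the result is a number 5 percentage points higher from compound 1 to compound 4 (within the scatter) on the shared core. At this aromatic carbon, para to a large group, this assay therefore does not separate the full arm, with its 12 heavy atoms, from bare hydrogen. No measurement shown bears on the reason for this result.

Still open, on these data alone, is how the read-out responds when a carboxylic acid or a morpholine sits on this carbon, since only the two extremes of arm and hydrogen can be compared here. Also open, as far as these compounds go, is whether the same tolerance holds when a longer chain replaces the butyl chain of compound 4.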